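The compounds below may be only part of what the source reports. "The series", "measured", "known", "first", "only" and "open" are said of these compounds alone.

In a functional assay on SN12C cells (Homo sapiens) for inhibition, read by sulforhodamine B assay, with a stated time of 48 h, tested at 10 uM (on this read-out higher numbers stand for more inhibition at the one concentration tested (going by the name of the read-out) and lower numbers for less inhibition), three compounds have been measured:

Compound 1 `c1ccc2c(-c3cn4ccnc4c(-c4ccc5ncn(C6CCCCC6)c5c4)n3)cccc2c1` gives 11.7%.
Compound 2 `c1ccc(Cn2cnc3ccc(-c4nc(-c5cccc6ccccc56)cn5ccnc45)cc32)cc1` gives 5.62%.
Compound 3 `c1cn2cc(-c3ccc4c(c3)ncn4C3CCCCC3)nc(-c3ccc4ncn(C5CCCCC5)c4c3)c2n1` gives 20.5%.

Compound 1 and compound 2 share a core and differ in one place: benzyl in place of cyclohexyl on an aromatic nitrogen. In this assay this change gave a number 6.1 percentage points lower from compound 1 to compound 2 (within the scatter). Compound 3 carries a different core from compound 1; the difference between the two cores is not broken down here. Compound 3 and compound 2 differ by more than the scatter, while compound 3 and compound 1 lie within it.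

Compound 4 `c1ccc(Cn2cnc3ccc(-c4nc(-c5ccc6c(c5)ncn6C5CCCCC5)cn5ccnc45)cc32)cc1` is not yet measured. It differs from compound 3 in exactly the way compound 2 differs from compound 1: benzyl in place of cyclohexyl on an aromatic nitrogen. The surroundings of the change are described in the same words for both pairs, so it is the same change on a different core. Going by the values given here, since the only earlier instance of this change, from compound 1 to compound 2, stayed within the scatter, compound 4 is expected to sit close to compound 3, with an estimated step of a number 6 percentage points lower from compound 3 to compound 4 (within the scatter) in this assay resting on a number 6.1 percentage points lower from compound 1 to compound 2 (within the scatter). On that basis compound 4 is estimated at 14.5% in this assay, likely between 4% and 25%.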

Compound 4, a percentage reported as inhibition, at one concentration (the size of the read-out at that concentration, not a potency): -35.4%
Beside the measured number, compound 4's estimate is 49.9 percentage points above it; the measured number lies below the stated range.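

In this assay, benzyl in place of cyclohexyl on an aromatic nitrogen gave a number 55.9 percentage points lower from compound 3 to compound 4 (beyond the scatter), and compound 4 stands at -35.4%, a negative number on a read-out of inhibition. The change therefore did not carry over at the same size, and its step on the core of compound 1 was no reliable guide to its step on the core of compound 3: the same change on two cores in this assay, a number 6.1 percentage points lower (within the scatter) from compound 1 to compound 2 and a number 55.9 percentage points lower (beyond the scatter) from compound 3 to compound 4, 49.8 percentage points apart, beyond the scatter of two such steps. Two pairs show only that the size of this step can differ between these cores; they do not show which feature of the cores sets that size, or what the step would be on any further core.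

The compounds shown leave open how the core of compound 3 responds to other groups on that nitrogen, such as a methyl or a longer chain ending in an amine. They also leave open whether the large step is tied to benzyl itself or would follow any replacement of cyclohexyl at that place.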